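Dimethylamino in Place of Methoxy on the Aryl Ring

A few compounds are considered here, and "the series" means these few. Any claim that something is new, unique, unknown or untested is made for them only; others in the source may bear on it.

Of the compounds shown here, two have been tested in a functional assay on aorta (strain Wistar) for inhibition, with Thoracic aorta (Rattus norvegicus) as the target; on this read-out higher numbers stand for weaker inhibition and lower numbers for stronger inhibition. Compound 1 `COc1nc(-c2cc3ccccc3o2)cc(-c2ccc(Cl)cc2)c1C#N` gives 286000 nM. Compound 2 `COc1ccc(-c2cc(-c3cc4ccccc4o3)nc(OC)c2C#N)cc1` gives 262000 nM. Going by the values given here, the two numbers lie within the scatter of each other: the step of a 1.1-fold lower number from compound 1 to compound 2 (0.04 log units; within the scatter) is the only measured comparison, and it shows that swapping the group on the phenyl ring between chloro and methoxy left the read-out essentially unchanged.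

Compound 3 `COc1nc(-c2cc3ccccc3o2)cc(-c2ccc(N(C)C)cc2)c1C#N` differs from compound 2 by dimethylamino in place of methoxy on an aromatic carbon. Among the compounds with values here, the single measured step that bears on this change, a 1.1-fold lower number from compound 1 to compound 2 (0.04 log units; within the scatter), concerned the same position and was within the scatter, so there is no basis in the data for expecting a shift beyond the scatter in this assay. Compound 3 is therefore estimated at 250000 nM, with a range of 100000 nM to 600000 nM, an expected step of a 1.0-fold lower number from compound 2 to compound 3 (0.02 log units; within the scatter).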

Compound 3, half-maximal inhibitory concentration: 278000 nM
Beside the measured number, compound 3's estimate is 1.1-fold (0.05 log units) below it; low and high end bracket the measured number.
By their numbers in this assay, from the lowest: compounds 2, 3 and 1 (each within the scatter of the next).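

In this assay this aromatic carbon now carries a third group with no step beyond the scatter: dimethylamino in place of methoxy gives a 1.1-fold higher number from compound 2 to compound 3 (0.03 log units; within the scatter) and dimethylamino in place of chloro gives a 1.0-fold lower number from compound 1 to compound 3 (0.01 log units; within the scatter). Chloro, methoxy and dimethylamino thus all lie within the scatter of one another, so the read-out does not tell these three groups apart at this position on the shared core. Nothing available explains why the three groups read alike.

Going by these compounds, whether a carboxylic acid, a primary amine or a longer chain on this same aromatic carbon would give a step beyond the scatter remains open. Also open, on these data alone, is whether any change elsewhere on the shared core would move the read-out at all.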